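This account rests on a few compounds, and the source may have more. Where it says the series, first, only, none or still open, it means among the compounds named here.

Of the compounds shown here, three have so far been measured in a functional assay on FM3A cells (Mus musculus) for antiproliferative activity, with a stated time of 48 h; a lower number here means a stronger inhibitor, a higher number a weaker inhibitor. Compound 1, `C=C(Br)C(=O)Nc1ccc(/C=C/C(=O)c2ccccc2)cc1`, gives in this assay 3900 nM. Compound 2, `C=C(Br)C(=O)Nc1ccc(/C=C/C(=O)c2cccc(OC)c2)cc1`, gives in this assay 2700 nM. Compound 3, `C=C(Br)C(=O)Nc1ccc(C(=O)/C=C/c2ccccc2OC)cc1`, gives in this assay 370 nM, the lowest of the three numbers, and both other numbers lie beyond the scatter from it. Compound 3 is built on a different core from compound 1, and the difference between the two cores is not broken down here.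

From compound 1 to compound 2 the change is methoxy in place of hydrogen on an aromatic carbon, and the step was a 1.4-fold lower number from compound 1 to compound 2 (0.16 log units; within the scatter).

Compound 4, `C=C(Br)C(=O)Nc1ccc(C(=O)/C=C/c2cccc(OC)c2OC)cc1`, has not yet been measured. It differs from compound 3 by methoxy in place of hydrogen on an aromatic carbon. Going by the values given here, this is the same kind of change as from compound 1 to compound 2, but not the same: in compound 4 the entering methoxy is ortho to a methoxy group, which has no counterpart in compound 2, while in both cases the place is meta to a large group.

A small step is expected, because the earlier instance of this change gave a 1.4-fold lower number from compound 1 to compound 2 (0.16 log units; within the scatter), a step within the scatter, and no other case of it is known among these compounds. The step expected here is a 1.2-fold lower number from compound 3 to compound 4 (0.09 log units; within the scatter). Compound 4 is therefore estimated to give about 300 nM in this assay, with a plausible range from 120 nM to 800 nM.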

Compound 4, half-maximal inhibitory concentration: 550 nM
The estimate for compound 4 lay 1.8-fold (0.26 log units) below the measured number; low and high end bracket the measured number.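

In this assay, methoxy in place of hydrogen on an aromatic carbon gave a 1.5-fold higher number from compound 3 to compound 4 (0.17 log units; within the scatter), so this second instance of the change is again a small step. Set beside the earlier instance, neither step stands out from the usual scatter of repeated measurements, and neither does the gap between them: the same change on two cores in this assay, a 1.4-fold lower number (0.16 log units; within the scatter) from compound 1 to compound 2 and a 1.5-fold higher number (0.17 log units; within the scatter) from compound 3 to compound 4, 2.1-fold (0.33 log units) apart, within the scatter of two such steps. Going by these compounds alone, this shows that, in these two instances, the change stays a step too small to read on either core, but it does not show that the two cores respond to it in the same way, as steps this small could hide a real difference, and the entering methoxy in compound 4 is ortho to a methoxy group, which has no counterpart in compound 2.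

The compounds shown test only methoxy as the entering group, on only two cores and in a single assay on one cell type. On these data alone, it remains open whether an amine, a carboxylic acid or a longer chain at these places would give a step beyond the scatter, and whether such a step would carry from one core to the other.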